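Series notes: three assay limits and one pending analogue

The source may report more compounds than this note shows. Statements on the series, on what has been measured and on what is new or still open speak of the compounds shown alone.

Measured so far in a physicochemical assay, with a stated time of 30 min; a lower number here means a stronger inhibitor, a higher number a weaker inhibitor:
compound 1 `CC(C)=N/N=C1\SCC(=O)N1Cc1ccc(N)cc1` gives > 5000000 nM, a limit of the assay.
compound 2 `O=C1CS/C(=N\N=C2CCCC2)N1Cc1ccc(Cl)cc1` gives > 5000000 nM, a limit of the assay.
compound 3 `C/C(=N\N=C1/SCC(=O)N1Cc1cccc(Cl)c1)c1ccccn1` gives > 5000000 nM, a limit of the assay.

For the measured compounds named here, compound 2 stands at the limit of this assay, and no measured compound in the set returns a number there: the limit of > 5000000 nM in this assay, at which 3 of the 3 values shown sit. Going by the values given here, no two measured compounds differ in only one place, so no measured step can be drawn from the values shown.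

Compound 4 `O=C1CS/C(=N\N=C2CCCC2)N1Cc1ccccc1F` has yet to be measured in this assay. Relative to compound 2 the change is 2-fluorophenyl in place of 4-chlorophenyl on a saturated chain carbon bound to an amide-type nitrogen in a ring. With every measured value a limit, there is no basis for expecting a step beyond the scatter in either direction; the step that the present estimate means, a number no higher from compound 2 to compound 4 (the limit leaves the size open), is expected to be none beyond the scatter. Compound 4 is estimated at 5000000 nM in this assay, within 1000000 nM to 50000000 nM, and the expected outcome is once more a limit rather than a number.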

Compound 4, half-maximal inhibitory concentration: > 5000000 nM
Compound 4: a limit, no number; the forecaster's own chance of this, stated with the estimate: 85%; the middle value lies on the limit itself.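

In this assay compound 4 gives > 5000000 nM, a limit of the assay. No step can be read from compound 2 to compound 4, as both values are limits: the limit of > 5000000 nM in this assay, at which 4 of the 4 values shown sit.

The compounds shown leave open whether any member of the series returns a number in this assay, and how 2-fluorophenyl and 4-chlorophenyl compare.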